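The compounds below may be only part of what the source reports. "The series", "measured", "known", "first", "only" and "open" are said of these compounds alone.

Measured in a functional assay on HCT-15 cells (Homo sapiens) for inhibition, read by sulforhodamine B assay, with a stated time of 72 h; a higher number here means a weaker inhibitor, a lower number a stronger inhibitor:

- compound 1 `COc1ccc(CN(Cc2ccccc2)Cc2c(O)ccc3c(=O)cc(C)oc23)cc1`: 10.7 ug/mL
- compound 2 `COc1ccc(CN(Cc2ccc3ccccc3c2)Cc2c(O)ccc3c(=O)cc(C)oc23)cc1`: 6.89 ug/mL

Compound 1 is the reference here, and the two values lie within the scatter of each other, so neither compound can be ranked. The next compound is compound 3 `COc1ccc(CN(Cc2ccc(OC)cc2)Cc2c(O)ccc3c(=O)cc(C)oc23)cc1`, with this change from compound 1: methoxy in place of hydrogen on an aromatic carbon. This turns a benzyl into a 4-methoxybenzyl. Among the measured compounds shown here, only one measured step touches that phenyl, a 1.6-fold lower number from compound 1 to compound 2 (0.19 log units; within the scatter), and it installs naphthalen-2-yl, a different group from methoxy. That single step stays within the scatter and offers no direction for methoxy in place of hydrogen, so no shift beyond the scatter is expected in this assay. The estimated step is a 1.1-fold lower number from compound 1 to compound 3 (0.05 log units; within the scatter). Compound 3 is expected at 9.5 ug/mL, with an estimated range of 4.5 ug/mL to 20 ug/mL.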

Compound 3, half-maximal inhibitory concentration: 53.7 ug/mL
For compound 3 the middle estimate is 5.7-fold (0.75 log units) below the measured one; measured number outside the range, above it.
By their numbers in this assay, from the lowest: compounds 2 and 1 (each within the scatter of the next); then compound 3.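

In this assay, the phenyl of the benzyl arm is not indifferent to substitution: methoxy in place of hydrogen gives a 5.0-fold higher number from compound 1 to compound 3 (0.70 log units; beyond the scatter), a step towards a weaker inhibitor that, unlike the step to naphthalen-2-yl, lies beyond the scatter. Compound 1 already carries one 4-methoxybenzyl on the amine nitrogen, so this change gives compound 3 a second one, and replacing naphthalen-2-yl with 4-methoxyphenyl gives a 7.8-fold higher number from compound 2 to compound 3 (0.89 log units; beyond the scatter). No measurement at hand bears on the reason for this shift.

As far as these compounds go, it remains open whether the shift belongs to methoxy itself or would also follow from a fluorine atom, a methyl group or a hydroxyl group on the same aromatic carbon. From the compounds shown here alone, it is also open whether replacing this benzyl with a simple alkyl chain would restore the number seen for compound 1.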